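The source may report more compounds than this note shows. Statements on the series, on what has been measured and on what is new or still open speak of the compounds shown alone.

Three compounds have been measured in a functional assay on SiHa cells (Homo sapiens) for cytotoxicity, with a stated time of 4 h; a lower number here means a stronger inhibitor, a higher number a weaker inhibitor:
compound 1 `Cc1ccc2c(c1)[n+]([O-])c(NCCN1CCCCC1)n[n+]2[O-]` gives 2200 nM;
compound 2 `CCCN(CCC)CCNc1n[n+]([O-])c2ccc(C)cc2[n+]1[O-]` gives 600 nM;
compound 3 `CC(C)(C)c1ccc2c(c1)[n+]([O-])c(NCCN1CCCCC1)n[n+]2[O-]` gives 600 nM.

Compound 2 differs from compound 1 by a single change, (dipropylamino in place of piperidin-1-yl on a saturated chain carbon, two bonds along the chain from a nitrogen on an aromatic ring), and that change brought a 3.7-fold lower number from compound 1 to compound 2 (0.56 log units; beyond the scatter). Compound 3 differs from compound 1 in its core, (tert-butyl in place of methyl on an aromatic carbon), which gave a 3.7-fold lower number from compound 1 to compound 3 (0.56 log units; beyond the scatter). Compound 4 `CCCN(CCC)CCNc1n[n+]([O-])c2ccc(C(C)(C)C)cc2[n+]1[O-]` has not yet been measured. Going by the values given here, it carries the same change as the one seen from compound 1 to compound 2, now made on the core of compound 3: dipropylamino in place of piperidin-1-yl on a saturated chain carbon, two bonds along the chain from a nitrogen on an aromatic ring. The place of the change is identical in both cases. Because the earlier change gave a 3.7-fold lower number from compound 1 to compound 2 (0.56 log units; beyond the scatter), a step of roughly that size is expected for compound 4, a 3.0-fold lower number from compound 3 to compound 4 (0.48 log units; beyond the scatter), although nothing here shows that the two changes add up fully. Compound 4 is therefore estimated at 200 nM in this assay.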

Compound 4, half-maximal inhibitory concentration: 3800 nM
Beside the measured number, compound 4's estimate is 19-fold (1.28 log units) below it, and the stated range ends below it.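

In this assay, the change from piperidin-1-yl to dipropylamino did not carry over from one core to the other, giving a 6.3-fold higher number from compound 3 to compound 4 (0.80 log units; beyond the scatter), opposite in direction to the earlier step: the same change on two cores in this assay, a 3.7-fold lower number (0.56 log units; beyond the scatter) from compound 1 to compound 2 and a 6.3-fold higher number (0.80 log units; beyond the scatter) from compound 3 to compound 4, 23-fold (1.37 log units) apart, beyond the scatter of two such steps

The change from methyl to tert-butyl reverses in the same way, giving a 6.3-fold higher number from compound 2 to compound 4 (0.80 log units; beyond the scatter) when dipropylamino is present: the same change on two cores in this assay, a 3.7-fold lower number (0.56 log units; beyond the scatter) from compound 1 to compound 3 and a 6.3-fold higher number (0.80 log units; beyond the scatter) from compound 2 to compound 4, 23-fold (1.37 log units) apart, beyond the scatter of two such steps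

So, in these four compounds, the effect of each change depends on the group present at the other place, but the numbers do not show why, or whether this holds on any other core.

The compounds shown leave open whether an ethyl or isopropyl group on that aromatic carbon would behave like methyl or like tert-butyl. They also leave open how a diethylamino group on the chain would respond.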